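Adding Two Bromines to the Hydroxy Compound

The source may report more compounds than this note shows. Statements on the series, on what has been measured and on what is new or still open speak of the compounds shown alone.

Measured in an ADME assay on HEK293 cells (Homo sapiens) for cytotoxicity, read by reporter gene assay and resazurin assay, with a stated time of 48 h; on this read-out lower numbers stand for higher toxicity in this test and higher numbers for lower toxicity in this test:
- Compound 1 `COc1ccc(Br)cc1C(=O)Nc1ccc(Sc2nc3ccccc3s2)cc1`: > 100000 nM (a limit)
- Compound 2 `COc1c(Br)cccc1C(=O)Nc1ccc(Sc2nc3ccccc3s2)cc1`: > 100000 nM (a limit)
- Compound 3 `O=C(Nc1ccc(Sc2nc3ccccc3s2)cc1)c1ccccc1O`: 74000 nM

In this assay, for the measured compounds named here, compound 3 gives 74000 nM, the only actual number in the set. The other two results mark (the limit of > 100000 nM in this assay, at which 2 of the 3 values shown sit).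

The next compound is compound 4 `O=C(Nc1ccc(Sc2nc3ccccc3s2)cc1)c1cc(Br)cc(Br)c1O`. The change is 3,5-dibromo-2-hydroxyphenyl in place of 2-hydroxyphenyl on a carbonyl carbon, with 3,5-dibromo-2-hydroxyphenyl in place of 2-hydroxyphenyl on a carbonyl carbon.

Going by the values given here, two measured steps bear on it, both involving compound 3: an at least 1.3-fold lower number from compound 1 to compound 3 (0.13 log units; that floor lies within the scatter) and an at least 1.3-fold lower number from compound 2 to compound 3 (0.13 log units; that floor lies within the scatter). Both are only floors, so neither fixes a size. The step that the two limits leave unreadable from compound 1 to compound 2 adds no size either. Bromine occurs so far only in compound 1 and compound 2, and both lack the free hydroxy group of compound 3. Among the compounds with values here, no measured step adds bromine to 2-hydroxyphenyl, so the direction of the change remains open.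

The expected move is therefore small, with a slight lean toward a lower number and a wide margin. The step of a 1.6-fold lower number from compound 3 to compound 4 (0.22 log units; within the scatter) is expected to stay within the scatter. Compound 4 is estimated at 45000 nM, with an expected range from 8000 nM to 100000 nM.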

Compound 4, half-maximal cytotoxic concentration: 66000 nM
Estimate against measurement, compound 4: 1.5-fold (0.17 log units) below, within the range that was stated.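

In this assay, 3,5-dibromo-2-hydroxyphenyl in place of 2-hydroxyphenyl on the carbonyl carbon gives a 1.1-fold lower number from compound 3 to compound 4 (0.05 log units; within the scatter), so the two values cannot be told apart. Compound 4 is the only compound shown that carries bromine together with the free hydroxy group, and it shows that at this position the two bromines leave the read-out inside the usual scatter when that hydroxy group stays in place. The steps from the two methoxy-bearing compounds, an at least 1.5-fold lower number from compound 1 to compound 4 (0.18 log units; that floor lies within the scatter) and an at least 1.5-fold lower number from compound 2 to compound 4 (0.18 log units; that floor lies within the scatter), remain floors that fix no size, as the starting values of those steps are limits and not numbers: the limit of > 100000 nM in this assay, at which 2 of the 4 values shown sit.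

For the compounds shown here, what a single bromine on 2-hydroxyphenyl would do stays open, since the only hydroxy compound with bromine carries two, and compound 4 cannot show whether each bromine alone would give the same result. As far as these compounds go, it is equally open whether a chlorine, an amine or a carboxylic acid on this ring would bring the number outside the scatter of compound 3 and compound 4.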